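A few compounds are considered here, and "the series" means these few. Any claim that something is new, unique, unknown or untested is made for them only; others in the source may bear on it.

In a functional assay on HT cells (Homo sapiens) for antiproliferative activity, read by fluorescence, with a stated time of 72 h (on this read-out lower numbers stand for stronger inhibition of growth and higher numbers for weaker inhibition of growth), compound 1 (`CSc1nc(NCc2ccc(-c3ccccn3)cc2)c2[nH]nc(C(C)C)c2n1`) gives 783 nM and compound 2 (`CC(C)c1n[nH]c2c(NCc3ccc(-c4ccccn4)cc3)nc(S)nc12`) gives 2760 nM as the higher of the two numbers. Compound 3 (`CC(C)c1n[nH]c2c(NCc3ccc(-c4ccccn4)cc3)nc(SCCn3ccnc3)nc12`) differs from compound 2 by 2-(1H-imidazol-1-yl)ethyl in place of hydrogen on a sulfur with 2-(1H-imidazol-1-yl)ethyl in place of hydrogen on a sulfur. Within the data shown here, the one measured step at this place, hydrogen in place of methyl on a sulfur, is a 3.5-fold higher number from compound 1 to compound 2 (0.55 log units; beyond the scatter) and is modest but beyond the scatter. Substituting the sulfur is therefore expected to lower the number by a similarly modest step, although no measured compound carries this group. The expected change is a 3.1-fold lower number from compound 2 to compound 3 (0.49 log units; beyond the scatter) in this estimate. In this assay the estimate for compound 3 is 900 nM with an expected range of 250 nM to 3000 nM as its two ends.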

Compound 3, concentration for 50% growth inhibition: 155 nM
The estimate for compound 3 lay 5.8-fold (0.76 log units) above the measured number; measured number below the stated range.
By their numbers in this assay, from the lowest: compound 3; then compound 1; then compound 2.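

In this assay the sulfur carries far more than a methyl: 2-(1H-imidazol-1-yl)ethyl in place of hydrogen gives an 18-fold lower number from compound 2 to compound 3 (1.25 log units; beyond the scatter) and, set against the methyl, gives a 5.1-fold lower number from compound 1 to compound 3 (0.70 log units; beyond the scatter). The number therefore keeps falling beyond the methyl, and compound 3 now has the lowest number of the three. Nothing at hand accounts for this fall. Going by these compounds, it remains open whether the five-membered aromatic ring or the chain alone carries the change, and how a longer alkyl chain, an amine or a carboxylic acid on this sulfur would compare.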